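The compounds below may be only part of what the source reports. "The series", "measured", "known", "first", "only" and "open" are said of these compounds alone.

Measured compounds in the series:

- compound 1, `CCCCCCCCc1ccc(OCC(=O)Cn2nnc(-c3ccccc3)n2)cc1`: 24 nM
- compound 2, `CCCCCCCCc1ccc(OCC(=O)Cn2nnc(-c3cccnc3)n2)cc1`: 23 nM

Both values come from an assay on microsomes from brain for inhibition of Fatty-acid amide hydrolase 1 (Rattus norvegicus), read by fluorescence and HPLC, with a stated time of 60 min; on this read-out higher numbers stand for weaker inhibition and lower numbers for stronger inhibition. Compound 1 stands at the higher of the two numbers, with compound 2 nearest; the step of a 1.0-fold lower number from compound 1 to compound 2 (0.02 log units; within the scatter) is within the scatter, so the two compounds cannot be ordered against each other. That step concerns only the aromatic ring on the tetrazole-bearing side of the core and says nothing about the chain between the ether oxygen and the carbonyl.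

Compound 3, `CCCCCCCCc1ccc(OC(C)C(=O)Cn2nnc(-c3ccccc3)n2)cc1`, is not yet measured. It differs from compound 1 by methyl in place of hydrogen on a saturated chain carbon bound to a carbonyl carbon and an oxygen on an aromatic ring. Going by the values given here, no measured step in this assay touches that chain carbon, so there is no precedent to scale the expectation by. In the absence of any relevant step, the working expectation for compound 3 in this assay is a number close to that of compound 1, with a wider range than the scatter alone would give.

The estimated step of a 1.3-fold higher number from compound 1 to compound 3 (0.10 log units; within the scatter) is expected to stay within the scatter. The expected value for compound 3 is 30 nM, with a range from 10 nM to 90 nM.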

Compound 3, half-maximal inhibitory concentration: 24 nM
The estimate for compound 3 lay 1.3-fold (0.10 log units) above the measured number, within the range that was stated.
By their numbers in this assay, from the lowest: compounds 2, 1 and 3 (each within the scatter of the next).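

In this assay, methyl in place of hydrogen on a saturated chain carbon bound to a carbonyl carbon and an oxygen on an aromatic ring gives no change at the digits printed from compound 1 to compound 3 (within the scatter) and thus provides the series' only reading at this position. The earlier step, pyridin-3-yl in place of phenyl, concerned a different part of the molecule, whereas this result shows that the chain carbon can carry this one added carbon without a readable shift in the number. No supporting measurement accompanies this result, so the data offer no explanation for it.

The result covers methyl alone and leaves open whether an ethyl group, a second methyl on the same carbon, a phenyl ring, an amine or a carboxylic acid at this chain carbon would also leave the number within the scatter. It also leaves open whether methyl at this position and pyridin-3-yl in place of phenyl would give a number within the scatter when both are present in one molecule.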